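Quinolin-2-yl in Place of Dichlorophenyl at the Saturated Ring Carbon

The source may hold more compounds than are shown below. What is called first, only, known or untested is meant among the compounds shown, and "the series" means these compounds.

Compound 2 `CC1=C(C(=O)OCC2CCN(C(=O)OC(C)(C)C)CC2)C(c2cc(Cl)cc(Cl)c2)C2=C(CC(C)(C)CC2=O)N1` gives the lowest of the two numbers in an assay on HEK293 cells for inhibition of neurogenic locus notch homolog protein 1 (Homo sapiens), read by a luciferase reporter and resazurin assay, with a stated time of 16 h (on this read-out lower numbers stand for stronger inhibition and higher numbers for weaker inhibition), with 640 nM; compound 1 `CC1=C(C(=O)OCC2CCN(C(=O)OC(C)(C)C)CC2)C(c2ccc3c(c2)OCCO3)C2=C(CC(C)(C)CC2=O)N1` gives 1520 nM. For the measured compounds named here, the one measured step, a 2.4-fold lower number from compound 1 to compound 2 (0.38 log units; beyond the scatter), concerns an aryl swap at the same saturated ring carbon and bears only loosely on the present change. Compound 3 `CC1=C(C(=O)OCC2CCN(C(=O)OC(C)(C)C)CC2)C(c2ccc3ccccc3n2)C2=C(CC(C)(C)CC2=O)N1` carries quinolin-2-yl in place of 3,5-dichlorophenyl on a saturated ring carbon. Nothing measured shows how a quinolin-2-yl group fares at that position, so the direction is open. Compound 3 is expected to give 1500 nM, between 400 nM and 6000 nM, a step of a 2.3-fold higher number from compound 2 to compound 3 (0.37 log units; beyond the scatter) in this assay whose size remains uncertain.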

Compound 3, half-maximal inhibitory concentration: 330 nM
Beside the measured number, compound 3's estimate is 4.5-fold (0.66 log units) above it, outside the stated range (below it).
By their numbers in this assay, from the lowest: compounds 3 and 2 (each within the scatter of the next); then compound 1.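

In this assay, for the compounds shown here, the saturated ring carbon accepts quinolin-2-yl, the first group here with a ring nitrogen, on a par with 3,5-dichlorophenyl, with a 1.9-fold lower number from compound 2 to compound 3 (0.29 log units; within the scatter). Against 2,3-dihydro-1,4-benzodioxin-6-yl, the same change gives a 4.6-fold lower number from compound 1 to compound 3 (0.66 log units; beyond the scatter), so this position separates these aryl groups only in part. No outside evidence bears on why these numbers fall as they do. The compounds shown leave open whether the ring nitrogen of quinolin-2-yl counts at all, as a naphthalen-2-yl group would test, and whether an amine or a carboxylic acid on this aryl group would be accepted.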